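This account rests on a few compounds, and the source may have more. Where it says the series, first, only, none or still open, it means among the compounds named here.

Compound 1: `COc1cc2cc(Oc3ccc(NC(=O)Nc4cccc(C(F)(F)F)c4)cc3)c(C)nc2cc1OC`; in a functional assay on NCI/ADR-RES cells (Homo sapiens) for inhibition, read by sulforhodamine B assay, with a stated time of 48 h (on this read-out lower numbers stand for higher toxicity in this test and higher numbers for lower toxicity in this test), compound 1 gives 40000 nM.
Compound 2: `COc1cc2cc(Oc3ccc(NC(=O)Nc4ccc(Cl)c(C(F)(F)F)c4)cc3)c(C)nc2cc1OC`; in this assay compound 2 reaches only a limit, > 32500 nM.

Compound 2 therefore stands at a limit of this assay, not at a number, as the limit of > 32500 nM in this assay, at which 1 of the 2 values shown sits, records. Compound 3 is `COc1cc2cc(Oc3ccc(NC(=O)Nc4ccc(Cl)c(Cl)c4)cc3)c(C)nc2cc1OC`, and the change from compound 2 is chloro in place of trifluoromethyl on an aromatic carbon. Among the measured compounds shown here, the only measured step, a step that the limit leaves unreadable from compound 1 to compound 2, is unreadable, so it gives no guide to size or direction. No shift beyond the scatter is expected, and this assay may again return only a limit. Compound 3 is expected at 40000 nM, between 15000 nM and 100000 nM. The expected step is a step that the limit leaves unreadable from compound 2 to compound 3.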

Compound 3, concentration lethal to 50% of the cells: > 100000 nM
Compound 3: only a limit was reported (the forecaster's own chance of this, stated with the estimate: 60%); middle value at least 2.5-fold (0.39 log units) away from the limit.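

Compound 3 reaches only a limit in this assay, > 100000 nM. Having 3,4-dichlorophenyl in place of 3-(trifluoromethyl)phenyl gives an at least 2.5-fold higher number from compound 1 to compound 3 (0.39 log units; beyond the scatter), and on this read-out a higher number stands for lower toxicity in this test. The step from trifluoromethyl to chloro itself cannot be read, as compound 2 and compound 3 both stand at limits.

As far as these compounds go, how far either compound lies past its limit stays open. So does whether a nitrile or an amine in this place would give a number rather than a limit.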